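A few compounds are considered here, and "the series" means these few. Any claim that something is new, unique, unknown or untested is made for them only; others in the source may bear on it.

Compound 1, `CCCCCCCCOc1nc(N)nc2c1ncn2/C=C1/CC1(CO)CO`, in an ADME assay on BCBL1 cells (Homo sapiens) for cytotoxicity, with a stated time of 7 days (on this read-out lower numbers stand for higher toxicity in this test and higher numbers for lower toxicity in this test), gives > 20000 nM, a limit of the assay and not a number.
Compound 2, `Nc1nc2c(ncn2/C=C2/CC2(CO)CO)c(=O)[nH]1`, gives > 20000 nM, again a limit rather than a number.
Compound 3, `Nc1nc(N2CCCC2)c2ncn(/C=C3/CC3(CO)CO)c2n1`, gives > 20000 nM, also only a limit.

Compound 3 therefore stands at the same limit as the other two measured compounds: the limit of > 20000 nM in this assay, at which 3 of the 3 values shown sit. For the measured compounds named here, the one step that can be traced among them, a step that the two limits leave unreadable from compound 1 to compound 3, is not readable, since both ends are limits. The unmeasured compound 4 is `CCCCCCOc1nc(N)nc2c1ncn2/C=C1/CC1(CO)CO`. Its change from compound 3 is hexyloxy in place of pyrrolidin-1-yl on an aromatic carbon. The comparison between compound 1 and compound 3 bears on this change, but it gives no size and no direction, so no step beyond the usual scatter can be expected in this assay. Compound 4 is thus expected to sit at or past the same limit, and the estimated step that the limit leaves unreadable from compound 3 to compound 4 is expected to be none that the assay can read. For compound 4 the estimate is 30000 nM, with a range from 10000 nM to 100000 nM.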

Compound 4, half-maximal cytotoxic concentration: > 20000 nM
Compound 4: only a limit was reported (the forecaster's own chance of this, stated with the estimate: 85%); the middle value is on the limit's open side.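

Compound 4 also gives a limit and not a number, so the steps to it from compound 1 and compound 3 cannot be read: the limit of > 20000 nM in this assay, at which 4 of the 4 values shown sit.

The compounds shown leave open whether octyloxy, hexyloxy and pyrrolidin-1-yl differ at all in this assay, since no compound here reaches a measurable toxic concentration.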